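The source may hold more compounds than are shown below. What is called first, only, known or untested is meant among the compounds shown, and "the series" means these compounds.

Among the measured compounds shown here, compound 1 `Cc1ccccc1S(=O)(=O)N1CCN(c2ccc(C(=O)NCc3cccs3)nn2)CC1` gives 0.92 in an ADME assay on microsomes from liver (Homo sapiens), read by LC-MS, using NADPH, tested at 10 uM (a higher number here means that the liver removes a larger share of the compound in one pass, a lower number that the liver removes a smaller share), the lowest of the two numbers so far. Compound 2 `Cc1ccccc1S(=O)(=O)N1CC=C(c2ccc(C(=O)NCc3ccc(F)cc3)nn2)CC1` gives 0.96 in this assay, a number within the scatter of that of compound 1, so no order between the two is claimed. Compound 3 `Cc1ccccc1S(=O)(=O)N1CCN(c2ccc(C(=O)NCc3ccc(F)cc3)nn2)CC1` is the unmeasured partner of compound 1: 4-fluorophenyl in place of thiophen-2-yl on a saturated chain carbon bound to an amide-type nitrogen. For the measured compounds named here, no step between two measured compounds bears directly on this change; compound 2 carries the entering 4-fluorobenzyl on a different core, and its value sits within the scatter of that of compound 1, which gives no ground for a shift in either direction. The step expected is a number 0.020 higher from compound 1 to compound 3 (within the scatter), with no direction beyond the scatter. The estimate for compound 3 in this assay is 0.94, with a range from 0.85 to 0.99.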

Compound 3, hepatic extraction ratio: 0.56
Beside the measured number, compound 3's estimate is 0.38 above it, and the stated range ends above it.
By their numbers in this assay, from the lowest: compound 3; then compounds 1 and 2 (each within the scatter of the next).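

In this assay, the exchange of thiophen-2-yl for 4-fluorophenyl on a saturated chain carbon bound to an amide-type nitrogen gives a large step, a number 0.36 lower from compound 1 to compound 3 (beyond the scatter), so the group at this position can move the number well beyond the scatter. The 4-fluorobenzyl does not bring a low number on every core: compound 2, which also carries it, gives 0.96. Nothing measured here accounts for the step.

Still open, as far as these compounds go, is whether the step comes from losing thiophen-2-yl or from gaining the fluorine, a question that plain phenyl or 4-chlorophenyl at this position would help to separate. From the compounds shown here alone, it is also open whether pyridin-3-yl, or a longer chain between the amide nitrogen and the ring, would keep the number near that of compound 3.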